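Extending the Ring Amine Side Chain in a Benzamide Agonist

This account rests on a few compounds, and the source may have more. Where it says the series, first, only, none or still open, it means among the compounds named here.

In a functional assay on HEK293 cells for agonist activity at 5-hydroxytryptamine receptor 4 (Homo sapiens), read by cAMP accumulation (a lower number here means that less compound is needed, a higher number that more compound is needed for the effect), compound 1 `COc1ccc2[nH]cc(C(=O)NCC3CCNCC3)c2c1` gives 6310 nM, whereas compound 2 `CCN1CCC(NC(=O)c2cc(Cl)c(N)cc2OC)CC1` gives 79.4 nM, the lower of the two numbers and the starting point here. Compound 3 `COc1cc(N)c(Cl)cc1C(=O)NC1CCN(CCCCCN2CCCCC2)CC1` is built from compound 2 by one change: 3-(piperidin-1-yl)propyl in place of hydrogen on a saturated chain carbon, two bonds along the chain from an amine nitrogen in a ring. Going by the values given here, no measured pair isolates a change of this kind, so any expectation leans only on the values of compound 2 and compound 1. The step from compound 2 to compound 3 is expected to be small, a 2.0-fold lower number from compound 2 to compound 3 (0.30 log units; within the scatter), and could fall within the scatter. In this assay compound 3 is therefore estimated at 40 nM, with a range from 8 nM to 200 nM.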

Compound 3, half-maximal effective concentration: 5.01 nM
Beside the measured number, compound 3's estimate is 8.0-fold (0.90 log units) above it; the whole stated range lies above it.
By their numbers in this assay, from the lowest: compound 3; then compound 2; then compound 1.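

In this assay the saturated chain carbon, two bonds along the chain from an amine nitrogen in a ring, takes 3-(piperidin-1-yl)propyl in place of hydrogen and gives a 16-fold lower number from compound 2 to compound 3 (1.20 log units; beyond the scatter), so this position tolerates a large extension and the number falls rather than rises. Compound 1 and compound 2 could not show this, as neither carries such an extension. Nothing measured here bears on why the number falls. From the compounds shown here alone, whether the step belongs to the chain or to its piperidine ring stays open. A shorter or longer chain, or a morpholine or dimethylamine at its end, would separate the two.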